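The source may report more compounds than this note shows. Statements on the series, on what has been measured and on what is new or still open speak of the compounds shown alone.

Measured so far:

Compound 1 `CCCNC(=O)c1cccc(C#Cc2ccccc2Nc2ncnc3ccc(Cl)nc23)c1` gives > 10000 nM in an assay on isolated protein for inhibition of MAP kinase-interacting serine/threonine-protein kinase 1 (Homo sapiens), read by HTRF, in the presence of a further agent that is not named here; a lower number here means a stronger inhibitor, a higher number a weaker inhibitor; this value is a limit of the assay, not a number.
Compound 2 `O=C(c1cccc(C#Cc2ccccc2Nc2ncnc3ccc(Cl)nc23)c1)N1CCNCC1` gives > 10000 nM in this assay; this too is a limit, not a number.
Compound 3 `Cc1c(C(=O)N2CCNCC2)oc2ccc(Nc3ncnc4ccc(Cl)nc34)cc12` gives > 10000 nM in this assay; again only a limit is reported.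

Compound 1 and compound 2 share one core and differ in a single place: propylamino in place of piperazin-1-yl on a carbonyl carbon. The step that the two limits leave unreadable from compound 2 to compound 1 cannot be given a size because both of its ends rest at the limit of > 10000 nM in this assay, at which 3 of the 3 values shown sit. Compound 3 is built on a different core from compound 2; the difference between the two cores is not broken down here.

Compound 4 `CCCNC(=O)c1oc2ccc(Nc3ncnc4ccc(Cl)nc34)cc2c1C` has not yet been measured. It arises from compound 3 by the same change that turns compound 2 into compound 1: propylamino in place of piperazin-1-yl on a carbonyl carbon. The place of the change is described in exactly the same words for both pairs, so the change is the same, only on the other core.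

For the expectation, the earlier step offers no readable size, and every value seen so far sits at the limit. The expected step from compound 3 to compound 4 in this assay is therefore small, a step that the limit leaves unreadable from compound 3 to compound 4. Compound 4 is estimated at 20000 nM, somewhere between 5000 nM and 100000 nM, and it is expected that the assay will again report only a limit rather than a number.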

Compound 4, half-maximal inhibitory concentration: > 10000 nM
Compound 4 gave a limit, no number; the forecaster's own chance of this, stated with the estimate: 80%; the middle value lies beyond the limit too.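

Compound 3 and compound 4 both sit at a limit of the assay rather than at a number, so the change from piperazin-1-yl to propylamino has no readable size on this core either: the limit of > 10000 nM in this assay, at which 4 of the 4 values shown sit.

The compounds shown leave open how strongly any of them inhibits in this assay, and whether either group does better than the other on either core.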